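Working notes: (4-fluorophenyl)carbonyl to methoxycarbonyl on the shared core

The compounds below may be only part of what the source reports. "The series", "measured", "known", "first", "only" and "open" are said of these compounds alone.

In a functional assay on A-375 cells (Homo sapiens) for cytotoxicity, read by MTT assay, with a stated time of 48 h (a lower number here means a stronger inhibitor, a higher number a weaker inhibitor), compound 3 `CC1(C)S[C@@H]2/C(=C\C(=O)c3ccc(F)cc3)C(=O)N2[C@H]1C(=O)OC(c1ccccc1)c1ccccc1` gives 17800 nM, the lowest of the two numbers recorded; compound 2 `CC1(C)S[C@@H]2/C(=C\C(=O)c3ccc([N+](=O)[O-])cc3)C(=O)N2[C@H]1C(=O)OC(c1ccccc1)c1ccccc1` gives 50300 nM. Within the data shown here, the only measured step is a 2.8-fold lower number from compound 2 to compound 3 (0.45 log units; beyond the scatter). Compound 1 `CC(=O)/C=C1\C[C@H]2SC(C)(C)[C@H](C(=O)OC(c3ccccc3)c3ccccc3)N2C1=O`, which carries a methyl on that carbonyl carbon, sits at the limit of > 100000 nM in this assay, at which 1 of the 3 values shown sits, and gives > 100000 nM. Compound 4 `COC(=O)/C=C1/C(=O)N2[C@@H]1SC(C)(C)[C@@H]2C(=O)OC(c1ccccc1)c1ccccc1` differs from compound 3 by methoxy in place of 4-fluorophenyl on a carbonyl carbon, a change at the carbonyl carbon itself rather than on the aromatic ring, so the step from compound 2 to compound 3 bears on it only loosely. Compound 1 and compound 3 together show that without the aromatic ring on that carbonyl only a limit is reached. An upward step beyond the scatter is therefore expected, a 3.4-fold higher number from compound 3 to compound 4 (0.53 log units; beyond the scatter). Compound 4 is estimated at 60000 nM, between 15000 nM and 200000 nM, with a fair chance that only a limit is reported.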

Compound 4, half-maximal inhibitory concentration: 24600 nM
For compound 4 the middle estimate is 2.4-fold (0.39 log units) above the measured one, and the stated range covers the measured number.
By their numbers in this assay, from the lowest: compounds 3 and 4 (each within the scatter of the next); then compound 2. At a limit, above all of these: compound 1.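

The 4-fluorophenyl on this carbonyl carbon is not required for the level of activity seen: with methoxy in its place there is a 1.4-fold higher number from compound 3 to compound 4 (0.14 log units; within the scatter), so the two groups cannot be ordered. Against 4-nitrophenyl, methoxy gives a 2.0-fold lower number from compound 2 to compound 4 (0.31 log units; beyond the scatter), so an aromatic ring on this carbonyl carbon does not by itself set the number. Compound 1 remains a limit, not a number: the limit of > 100000 nM in this assay, at which 1 of the 4 values shown sits. As far as these compounds go, whether an amine, a carboxylic acid or a longer chain in place of the methoxy would keep the number of compound 4 stays open.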